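A Second Chloro Group on the Aryl Sulfonamide of Compound 1

The source may report more compounds than this note shows. Statements on the series, on what has been measured and on what is new or still open speak of the compounds shown alone.

Two sulfonamides have been measured so far. In a functional assay on MIA PaCa-2 cells (Homo sapiens) for inhibition, read by MTT assay, with a stated time of 72 h (on this read-out lower numbers stand for stronger inhibition of growth and higher numbers for weaker inhibition of growth), compound 1 `O=S(=O)(NCCCCCCNCc1ccc(Br)cc1)c1ccccc1Cl` gives 13700 nM, the highest of the two numbers; compound 2 `COc1cccc(CNCCCNS(=O)(=O)c2cc(C(F)(F)F)cc(C(F)(F)F)c2)c1` gives 3400 nM in this assay, a gap that lies beyond the scatter. Compound 3 `O=S(=O)(NCCCCCCNCc1ccc(Br)cc1)c1c(Cl)cccc1Cl` is the untested analogue of compound 1, differing by chloro in place of hydrogen on an aromatic carbon: the aryl group goes from 2-chlorophenyl to 2,6-dichlorophenyl. Going by the values given here, with no measured pair showing this change, only a small shift in this assay is expected, towards a slightly lower number if any. Compound 3 is estimated at 9000 nM, between 3000 nM and 27000 nM, an expected step of a 1.5-fold lower number from compound 1 to compound 3 (0.18 log units; within the scatter).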

Compound 3, concentration for 50% growth inhibition: 14700 nM
For compound 3 the middle estimate is 1.6-fold (0.21 log units) below the measured one; the measured number falls inside the stated range.
By their numbers in this assay, from the lowest: compound 2; then compounds 1 and 3 (each within the scatter of the next).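

In this assay, this first pair differing in one place gives a 1.1-fold higher number from compound 1 to compound 3 (0.03 log units; within the scatter), so compound 1 and compound 3 cannot be told apart on this read-out. A chloro group ortho to a large group and meta to a chloro group is thus tolerated here, at least in this single pair, with the 2,6-dichlorophenyl group matching the 2-chlorophenyl group. Nothing available explains this result. Still open, from the compounds shown here alone, is whether a nitrile or an amine on this same aromatic carbon would give a step beyond the scatter. Going by these compounds, whether the second chloro group would behave the same way on a different aryl sulfonamide is also open.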